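The compounds below may be only part of what the source reports. "The series", "measured", "known", "first", "only" and "open" are said of these compounds alone.

Compound 1 `N#CC1=C(N)Oc2c(N)cc3nc4ccccc4nc3c2C12C(=O)N(Cc1cnnn1-c1ccc(Cl)cc1)c1ccccc12`: in an ADME assay on L02 cells (Homo sapiens) for antiproliferative activity, read by MTT assay, with a stated time of 48 h (a higher number here means a weaker inhibitor, a lower number a stronger inhibitor), compound 1 gives > 50000 nM, a limit of the assay rather than a number.
Compound 2 `N#CC1=C(N)Oc2c(N)cc3nc4ccccc4nc3c2C12C(=O)N(Cc1cnnn1-c1cccc(C(F)(F)F)c1)c1ccccc12`: in this assay compound 2 gives 38100 nM.
Compound 3 `CCOc1ccccc1-n1nncc1CN1C(=O)C2(C(C#N)=C(N)Oc3c(N)cc4nc5ccccc5nc4c32)c2ccccc21`: in this assay compound 3 gives > 50000 nM, again a limit of the assay.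

Compound 3 thus stands at the limit of > 50000 nM in this assay, at which 2 of the 3 values shown sit, with no number of its own. Compound 4 `Cc1ccc(-n2nncc2CN2C(=O)C3(C(C#N)=C(N)Oc4c(N)cc5nc6ccccc6nc5c43)c3ccccc32)cc1C` differs from compound 3 by 3,4-dimethylphenyl in place of 2-ethoxyphenyl on an aromatic nitrogen. Among the compounds with values here, the measured steps at this same aromatic nitrogen are the only guide: an at least 1.3-fold lower number from compound 1 to compound 2 (0.11 log units; that floor lies within the scatter), an at least 1.3-fold higher number from compound 2 to compound 3 (0.11 log units; that floor lies within the scatter) and a step that the two limits leave unreadable from compound 1 to compound 3. None of them is readable beyond the scatter. Compound 4 is therefore expected to show no step beyond the scatter in this assay, most likely sitting at the limit again. The estimate for compound 4 is 50000 nM, between 25000 nM and 100000 nM. This expectation amounts to a number no higher from compound 3 to compound 4 (the limit leaves the size open).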

Compound 4, half-maximal inhibitory concentration: > 50000 nM
Compound 4: only a limit was reported; the forecaster's own chance of this, stated with the estimate: 65%; the middle value lies on the limit itself.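

With 3,4-dimethylphenyl, which carries no oxygen, compound 4 gives only a limit of the assay in this assay, so the change from 2-ethoxyphenyl brings no readable gain. Within the data shown here, the one step that can be read is an at least 1.3-fold higher number from compound 2 to compound 4 (0.11 log units; that floor lies within the scatter), and the other new steps cannot be read. Three different groups, 4-chlorophenyl, 2-ethoxyphenyl and 3,4-dimethylphenyl, now end at the same limit, with compound 2 the only exception: the limit of > 50000 nM in this assay, at which 3 of the 4 values shown sit.

The compounds shown leave open whether any group on this aromatic nitrogen gives a step beyond the scatter. From the compounds shown here alone, how a carboxylic acid on the phenyl ring, or an amine there, would read remains unknown.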